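The source may hold more compounds than are shown below. What is called first, only, known or untested is meant among the compounds shown, and "the series" means these compounds.

Within the data shown here, in a functional assay on MHCC97H cells (Homo sapiens) for antiproliferative activity, read by MTT assay, with a stated time of 48 h (on this read-out higher numbers stand for weaker inhibition and lower numbers for stronger inhibition), compound 2 (`COc1cc(C(=O)/C=C/c2cn(C)c3ccccc23)cc([N+](=O)[O-])c1OC`) gives 850 nM, the higher of the two numbers so far, while compound 1 (`COc1ccc2c(/C=C/C(=O)c3cc(OC)c(OC)c(SC)c3)cn(C)c2c1`) gives 122 nM, a gap beyond the scatter. Compound 3 (`COc1ccc2c(/C=C/C(=O)c3cc(OC)c(OC)c([N+](=O)[O-])c3)cn(C)c2c1`) departs from compound 2 by one change: methoxy in place of hydrogen on an aromatic carbon. Among the measured compounds shown here, compound 1 also carries that methoxy but differs elsewhere too, so no single-place step has been measured. A move to a lower number in this assay, beyond the scatter, is expected, and the estimated step is a 3.4-fold lower number from compound 2 to compound 3 (0.53 log units; beyond the scatter). For compound 3 the estimated value is 250 nM, with an expected range of 70 nM to 800 nM.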

Compound 3, half-maximal inhibitory concentration: 562 nM
For compound 3 the middle estimate is 2.2-fold (0.35 log units) below the measured one; the range from low to high includes it.
By their numbers in this assay, from the lowest: compound 1; then compounds 3 and 2 (each within the scatter of the next).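

In this assay, methoxy in place of hydrogen on an aromatic carbon of the fused system gives a 1.5-fold lower number from compound 2 to compound 3 (0.18 log units; within the scatter), so this change alone does not separate the two compounds. Nitro in place of methylsulfanyl on an aromatic carbon gives a 4.6-fold higher number from compound 1 to compound 3 (0.66 log units; beyond the scatter), and this step, unlike the methoxy step, lies beyond the scatter. No evidence is available to explain either step. The compounds shown leave open whether a hydroxy group at the methoxy site, or an amine in place of the nitro, would give a step beyond the scatter.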